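This account rests on a few compounds, and the source may have more. Where it says the series, first, only, none or still open, it means among the compounds named here.

For the measured compounds named here, compound 3 `COc1cc(-c2nnc(SCc3ccccc3)o2)ccc1O` is measured in an ADME assay on cells (Mus musculus, strain BALB/c) for cytotoxicity, read by MTT assay, with a stated time of 24 h (a lower number here means that less compound is tolerated, a higher number that more compound is tolerated), at 211000 nM, the lowest of the three numbers so far. Compound 1 `COc1cc(-c2nnc(SCc3cccc(Cl)c3)o2)ccc1O` gives 470000 nM in this assay, and compound 2 `COc1cc(-c2nnc(SCc3ccccc3C)o2)ccc1O` gives 592000 nM; the steps of a 2.2-fold lower number from compound 1 to compound 3 (0.35 log units; beyond the scatter) and a 2.8-fold lower number from compound 2 to compound 3 (0.45 log units; beyond the scatter) both lie beyond the scatter, while a 1.3-fold higher number from compound 1 to compound 2 (0.10 log units; within the scatter) does not.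

Compound 4 `COc1cc(-c2nnc(SCc3ccc(Br)cc3)o2)ccc1O` differs from compound 3 by bromo in place of hydrogen on an aromatic carbon, sitting on an aromatic carbon of a six-membered aromatic ring of carbon only. The two steps that bear on this, a 2.2-fold lower number from compound 1 to compound 3 (0.35 log units; beyond the scatter) and a 2.8-fold lower number from compound 2 to compound 3 (0.45 log units; beyond the scatter), show that removing a substituent from that ring gave lower numbers. Adding one is therefore expected to go the other way, as a 2.1-fold higher number from compound 3 to compound 4 (0.33 log units; beyond the scatter), so compound 4 is estimated at 450000 nM, with a likely range from 200000 nM to 1000000 nM.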

Compound 4, half-maximal cytotoxic concentration: 455000 nM
The estimate for compound 4 lay 1.0-fold (0.00 log units) below the measured number; low and high end bracket the measured number.
By their numbers in this assay, from the lowest: compound 3; then compounds 4, 1 and 2 (each within the scatter of the next).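

Bromo on an aromatic carbon, para to a large group, also gives a higher number in this assay (a 2.2-fold higher number from compound 3 to compound 4 (0.33 log units; beyond the scatter)), so compound 3 now stands below three substituted compounds. The 4-bromophenyl group cannot be told apart from 2-methylphenyl (a 1.3-fold lower number from compound 2 to compound 4 (0.11 log units; within the scatter)) or 3-chlorophenyl (a 1.0-fold lower number from compound 1 to compound 4 (0.01 log units; within the scatter)), so the identity of these three groups makes no readable difference here. Nothing available explains these steps.

From the compounds shown here alone, whether an amine or a carboxylic acid on this ring would give a similar number remains open. So does the effect of a longer chain between the sulfur and the ring.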